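This account rests on a few compounds, and the source may have more. Where it says the series, first, only, none or still open, it means among the compounds named here.

Compound 1 `Cc1ccc(NC(=O)Nc2cccc(-c3cccc4[nH]nc(N)c34)c2)cc1` carries a 4-methylphenyl on an amide-type nitrogen. In a functional assay on A549 cells (Homo sapiens) for inhibition, read by MTT assay, with a stated time of 48 h (a lower number here means a stronger inhibitor, a higher number a weaker inhibitor), compound 1 gives 1660 nM. Of the two numbers in hand it stands as the higher, but compound 2 `Nc1n[nH]c2cccc(-c3cccc(NC(=O)Nc4cccc(F)c4)c3)c12`, which gives 1360 nM, lies very close: the step of a 1.2-fold lower number from compound 1 to compound 2 (0.09 log units; within the scatter) is within the scatter, so these two compounds cannot be told apart on this evidence. Compound 3 `Nc1n[nH]c2cccc(-c3cccc(NC(=O)Nc4ccc(Cl)cc4Cl)c3)c12` is a different case: for compound 3 this assay reports only a limit, > 500000 nM, and not a number. The steps of an at least 300-fold higher number from compound 1 to compound 3 (2.47 log units; beyond the scatter) and an at least 360-fold higher number from compound 2 to compound 3 (2.56 log units; beyond the scatter) are both large, and the limit of > 500000 nM in this assay, at which 1 of the 3 values shown sits, marks where that compound sits.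

Compound 4 `COc1cccc(NC(=O)Nc2cccc(-c3cccc4[nH]nc(N)c34)c2)c1` has not yet been measured. It differs from compound 1 in one place: 3-methoxyphenyl in place of 4-methylphenyl on an amide-type nitrogen. Among the measured compounds shown here, two measured steps bear on such a swap. Replacing 4-methylphenyl by 3-fluorophenyl left the number essentially unchanged, while replacing it by 2,4-dichlorophenyl removed measurable activity altogether. A 3-methoxyphenyl resembles 3-fluorophenyl and 4-methylphenyl far more than it resembles 2,4-dichlorophenyl, so only a small step, if any beyond the scatter, is expected. Compound 4 is therefore expected to give about 1500 nM, within 500 nM and 5000 nM. That would mean an expected step of a 1.1-fold lower number from compound 1 to compound 4 (0.04 log units; within the scatter).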

Compound 4, half-maximal inhibitory concentration: 2490 nM
Compound 4: the middle estimate sits 1.7-fold (0.22 log units) below what was measured; the measured number falls inside the stated range.
By their numbers in this assay, from the lowest: compounds 2, 1 and 4 (each within the scatter of the next). At a limit, above all of these: compound 3.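

The steps of a 1.5-fold higher number from compound 1 to compound 4 (0.18 log units; within the scatter) and a 1.8-fold higher number from compound 2 to compound 4 (0.26 log units; within the scatter) show that this place on the amide-type nitrogen accepts 3-methoxyphenyl, which brings an oxygen and a hydrogen-bond acceptor absent from 4-methylphenyl, without a difference that can be told from the scatter. Compounds 1, 2 and 4 therefore form a group of three that this assay cannot separate, and compound 3, with its 2,4-dichlorophenyl, goes against that pattern, as the large step of an at least 200-fold lower number from compound 3 to compound 4 (2.30 log units; beyond the scatter) shows. Compound 3 is reported only as a limit: the limit of > 500000 nM in this assay, at which 1 of the 4 values shown sits.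

Still open, as far as these compounds go, is whether the large step belongs to the chlorine atoms themselves or to the ring carrying two groups rather than one, a question that a phenyl ring with a single chloro could help to settle. Also open, from the compounds shown here alone, is how the number would respond to a group of a quite different kind on this ring, such as an amine or a carboxylic acid in place of the methoxy.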